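Ethylamino for Ethyl on the Carbonyl of Compound 3

The source may report more compounds than this note shows. Statements on the series, on what has been measured and on what is new or still open speak of the compounds shown alone.

Measured in an assay on isolated protein for binding affinity to melatonin receptor type 1B (Homo sapiens); a higher number here means a weaker inhibitor, a lower number a stronger inhibitor:
compound 1 `CCCC(=O)Nc1cccc(Oc2cccc(OC)c2)c1` gives 26.8 nM
compound 2 `CCCC(=O)Nc1ccc(Oc2ccc(OC)cc2)cc1` gives > 400 nM, which is a limit rather than a number
compound 3 `CCC(=O)Nc1ccc(Oc2cccc(OC)c2)cc1` gives 6.8 nM

Of the two real numbers, compound 3 stands lowest, with compound 1 higher by a gap beyond the usual scatter. Compound 2 sits at the limit of > 400 nM in this assay, at which 1 of the 3 values shown sits, so it gives no number to compare.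

Compound 4 `CCNC(=O)Nc1ccc(Oc2cccc(OC)c2)cc1` has not been measured. It differs from compound 3 by ethylamino in place of ethyl on a carbonyl carbon. Among the compounds with values here, no measured pair shows this change, so the expectation rests on compound 3 alone. The step is expected to be a moderate weakening, a 3.7-fold higher number from compound 3 to compound 4 (0.57 log units; beyond the scatter), beyond the scatter but not large. Compound 4 is therefore expected to give about 25 nM in this assay, within a range from 8 nM to 100 nM.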

Compound 4, inhibition constant: 250 nM
Estimate against measurement, compound 4: 10-fold (1.00 log units) below, outside the stated range (above it).
By their numbers in this assay, from the lowest: compound 3; then compound 1; then compound 4. At a limit, above all of these: compound 2.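

Swapping propanoylamino for (ethylcarbamoyl)amino adds just one nitrogen atom, yet in this assay it gives a 37-fold higher number from compound 3 to compound 4 (1.57 log units; beyond the scatter). This single pair shows that binding is sensitive to what sits on this carbonyl carbon, and that a small change in atoms can carry a large change in the number. Nothing measured here explains the size of this loss.

From the compounds shown here alone, whether the loss follows the added nitrogen or the greater length of the group remains open. Ethoxy or methylamino on the same carbonyl carbon would help to separate the two.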